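The source may report more compounds than this note shows. Statements on the series, on what has been measured and on what is new or still open speak of the compounds shown alone.

Measured in a functional assay on U-87MG ATCC cells for antiproliferative activity against U-87 MG (Homo sapiens), read by MTT assay, with a stated time of 48 h; a higher number here means a weaker inhibitor, a lower number a stronger inhibitor:
compound 1 `Cc1nc(-c2ccccc2)sc1C(=O)CSc1nc(N)c(C#N)c(-c2ccc(Cl)cc2)n1` gives 10800 nM
compound 2 `Cc1nc(-c2ccc(Cl)cc2)sc1C(=O)CSc1nc(N)c(C#N)c(-c2ccc(Cl)cc2)n1` gives 3420 nM
compound 3 `COc1ccc(-c2nc(C)c(C(=O)CSc3nc(-c4ccccc4)c(C#N)c(=O)[nH]3)s2)cc1` gives 57300 nM

Compound 2 differs from compound 1 by chloro in place of hydrogen on an aromatic carbon, sitting para to a large group; this change gave a 3.2-fold lower number from compound 1 to compound 2 (0.50 log units; beyond the scatter). Compound 3 carries a different core from compound 1; the difference between the two cores is not broken down here, and compound 3 gives the highest of the three numbers in this assay. Compound 4 `COc1ccc(-c2nc(C)c(C(=O)CSc3nc(-c4cccc(Cl)c4)c(C#N)c(=O)[nH]3)s2)cc1`, not yet measured, differs from compound 3 by chloro in place of hydrogen on an aromatic carbon, here sitting meta to a large group rather than para, so it is the same kind of change as that between compound 1 and compound 2, not the same one. Within the data shown here, the only precedent in this assay was recorded on another core and with the chloro para, so how far it carries over is uncertain. For compound 4 a somewhat smaller step is expected, a 2.3-fold lower number from compound 3 to compound 4 (0.36 log units; beyond the scatter), resting on a 3.2-fold lower number from compound 1 to compound 2 (0.50 log units; beyond the scatter). Compound 4 is estimated at 25000 nM, with a range from 10000 nM to 60000 nM.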

Compound 4, half-maximal inhibitory concentration: 78900 nM
Compound 4: the middle estimate sits 3.2-fold (0.50 log units) below what was measured; the whole stated range lies below it.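

In this assay, replacing phenyl with 3-chlorophenyl on the core of compound 3 gives a 1.4-fold higher number from compound 3 to compound 4 (0.14 log units; within the scatter), so the step seen on the core of compound 1 does not reappear there. Chloro in place of hydrogen on an aromatic carbon therefore cannot be carried from one core to the other in this series as a fixed step: the same change on two cores in this assay, a 3.2-fold lower number (0.50 log units; beyond the scatter) from compound 1 to compound 2 and a 1.4-fold higher number (0.14 log units; within the scatter) from compound 3 to compound 4, 4.3-fold (0.64 log units) apart, beyond the scatter of two such steps

Among these compounds, this does not show that the core alone sets the outcome, since the chloro sits para to a large group in compound 2 and meta to a large group in compound 4, and each core offers only a single pair.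

Among the compounds shown here, still open is whether chloro para to a large group on the core of compound 3 would give a step like the one from compound 1 to compound 2, which would separate core from position. Also open, as far as these compounds go, is whether a carboxylic acid or a longer alkyl chain in that place would move the number on either core.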